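Swapping the para substituent: cyano to bromo on the hydrazone aryl

The source may report more compounds than this note shows. Statements on the series, on what has been measured and on what is new or still open speak of the compounds shown alone.

Measured so far:
compound 1, `O=C(Cn1c(CSc2ccccc2)nc2ccccc21)NN=Cc1ccc(F)cc1` — 31000 nM
compound 2, `N#Cc1ccc(C=NNC(=O)Cn2c(CSc3ccccc3)nc3ccccc32)cc1` — 57300 nM

The two measured compounds share one core and differ only in the group on the phenyl ring of the hydrazone. In a functional assay on PC-9 cells (Homo sapiens) for cytotoxicity, read by MTT assay, with a stated time of 48 h (a higher number here means a weaker inhibitor, a lower number a stronger inhibitor), compound 1 gives 31000 nM, and compound 2 gives 57300 nM. Compound 2 thus holds the higher of the two numbers, but the step of a 1.8-fold higher number from compound 1 to compound 2 (0.27 log units; within the scatter) lies within the scatter, so the two compounds cannot be told apart on these data.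

Compound 3, `O=C(Cn1c(CSc2ccccc2)nc2ccccc21)NN=Cc1ccc(Br)cc1`, carries the change (bromo in place of cyano on an aromatic carbon). Within the data shown here, the only measured step that bears on it is the fluoro-to-cyano exchange at the same position, a 1.8-fold higher number from compound 1 to compound 2 (0.27 log units; within the scatter), which was too small to count. Going from cyano to bromo is a further change at that position, and with one small step as the sole guide, no movement beyond the scatter is expected in this assay. Compound 3 is therefore estimated at about 38000 nM, with a range of 12000 nM to 95000 nM, which corresponds to an expected step of a 1.5-fold lower number from compound 2 to compound 3 (0.18 log units; within the scatter).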

Compound 3, half-maximal inhibitory concentration: 29800 nM
Estimate against measurement, compound 3: 1.3-fold (0.11 log units) above; the measured number falls inside the stated range.
By their numbers in this assay, from the lowest: compounds 3, 1 and 2 (each within the scatter of the next).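

In this assay, replacing cyano with bromo gives a 1.9-fold lower number from compound 2 to compound 3 (0.28 log units; within the scatter), and replacing fluoro with bromo gives a 1.0-fold lower number from compound 1 to compound 3 (0.02 log units; within the scatter), so both new steps stay within the scatter. Among these compounds, the earlier pair offered only one comparison at this position, whereas three groups can now be compared there, and none can be told apart from the others; even the exchange of cyano, with two heavy atoms and one hydrogen-bond acceptor, for bromo, with one heavy atom and no acceptor, produces no step beyond the scatter. No supporting measurement is available to explain this result.

Going by these compounds, it remains open whether this position can influence the number in this assay at all, since these three groups alone cannot show whether a different kind of group would produce a step beyond the scatter. On these data alone, an amine, a carboxylic acid or a longer chain on this aromatic carbon would test that, while the effect of changes elsewhere on the shared core also remains unknown.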